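From benzylamino to 4-methoxyphenyl on the carbonyl carbon

The source may hold more compounds than are shown below. What is called first, only, known or untested is meant among the compounds shown, and "the series" means these compounds.

In a functional assay on MDA-MB-231 cells (Homo sapiens) for antiproliferative activity, read by MTT assay, with a stated time of 72 h (on this read-out higher numbers stand for weaker inhibition and lower numbers for stronger inhibition), compound 1 `CC1=CC[C@H]2[C@H](CC[C@]2(C)O)C(C)(C)[C@@H]1CC[C@H]1[C@]2(C)CC[C@H](OC(=O)c3ccccc3)C(C)(C)O[C@H]2CC[C@@]1(C)O` gives 16100 nM and compound 2 `CC1=CC[C@H]2[C@H](CC[C@]2(C)O)C(C)(C)[C@@H]1CC[C@H]1[C@]2(C)CC[C@H](OC(=O)c3ccc(Cl)cc3)C(C)(C)O[C@H]2CC[C@@]1(C)O` gives 10300 nM on the shared core, with phenyl and 4-chlorophenyl on the carbonyl carbon. The step of a 1.6-fold lower number from compound 1 to compound 2 (0.19 log units; within the scatter) stays within the scatter. Compound 3 `CC1=CC[C@H]2[C@H](CC[C@]2(C)O)C(C)(C)[C@@H]1CC[C@H]1[C@]2(C)CC[C@H](OC(=O)NCc3ccccc3)C(C)(C)O[C@H]2CC[C@@]1(C)O` at 40300 nM has the highest number of the three, and its steps to both others lie beyond the scatter.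

Compound 4 `COc1ccc(C(=O)O[C@H]2CC[C@]3(C)[C@H](CC[C@@](C)(O)[C@H]3CC[C@@H]3C(C)=CC[C@H]4[C@H](CC[C@]4(C)O)C3(C)C)OC2(C)C)cc1` is the next case: 4-methoxyphenyl in place of benzylamino on a carbonyl carbon describes the change, 4-methoxyphenyl in place of benzylamino on a carbonyl carbon. This puts a substituted phenyl back on the carbonyl carbon, as in compound 2. Going by the values given here, the steps that bear on it are a 2.5-fold higher number from compound 1 to compound 3 (0.40 log units; beyond the scatter) and a 3.9-fold higher number from compound 2 to compound 3 (0.59 log units; beyond the scatter) and both are modest; compound 4 would run them in reverse. Among the compounds with values here, no methoxy compound has been measured, so the chloro step is the only guide to a change on the phenyl ring. A modest step to a lower number is therefore expected, and the estimated move is a 2.9-fold lower number from compound 3 to compound 4 (0.46 log units; beyond the scatter) in this assay for this pair. Compound 4 is expected at 14000 nM with an estimated range of 7000 nM to 28000 nM in this series.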

Compound 4, half-maximal inhibitory concentration: 30600 nM
Beside the measured number, compound 4's estimate is 2.2-fold (0.34 log units) below it, outside the stated range (above it).
By their numbers in this assay, from the lowest: compounds 2, 1, 4 and 3 (each within the scatter of the next, the first and the last beyond it).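

In this assay, the step of a 1.3-fold lower number from compound 3 to compound 4 (0.12 log units; within the scatter) shows that 4-methoxyphenyl in place of benzylamino on the carbonyl carbon does not clearly separate the two compounds, so a phenyl-type group at this position does not by itself set the number apart from the benzylamino compound. The ring substituent now shows a first clear difference: a 3.0-fold higher number from compound 2 to compound 4 (0.47 log units; beyond the scatter) lies beyond the scatter, whereas a 1.9-fold higher number from compound 1 to compound 4 (0.28 log units; within the scatter) stays within it, so methoxy separates from chloro but not from hydrogen on the aromatic carbon, and the series has no single trend running through hydrogen, chloro and methoxy. Nothing at hand explains these steps.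

Going by these compounds, with only chloro and methoxy on the phenyl ring, it remains open whether the difference between them extends to other ring groups, such as a dimethylamino group or a carboxylic acid. On these data alone, a longer chain on the carbonyl carbon also remains untested in these compounds, so how far this position tolerates a larger change stays open.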